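Compound 2 to compound 3: a shorter carboxy chain

A few compounds are considered here, and "the series" means these few. Any claim that something is new, unique, unknown or untested is made for them only; others in the source may bear on it.

In a functional assay on A549 cells (Homo sapiens) for cytotoxicity, read by MTT assay, with a stated time of 72 h (on this read-out lower numbers stand for stronger inhibition and higher numbers for weaker inhibition), compound 1 `CC1=CCC[C@H]2[C@](C)(CC3=CC(=O)C=CC3=O)[C@@H](C)CC[C@]12C` gives 30000 nM and compound 2 `CSCC[C@H](NC1=CC(=O)C=C(C[C@]2(C)[C@@H](C)CC[C@]3(C)C(C)=CCC[C@@H]23)C1=O)C(=O)O` gives 47300 nM as its value, so the two numbers lie within the usual scatter of each other. In compound 3 `CC1=CCC[C@H]2[C@](C)(CC3=CC(=O)C=C(NCCC(=O)O)C3=O)[C@@H](C)CC[C@]12C` the shared core stays, while 2-carboxyethyl stands in place of 1-carboxy-3-(methylsulfanyl)propyl on an amine nitrogen (2-carboxyethyl in place of 1-carboxy-3-(methylsulfanyl)propyl on an amine nitrogen). Among the compounds with values here, one measured step bears on this. Putting (1-carboxy-3-(methylsulfanyl)propyl)amino in place of hydrogen on a double-bonded ring carbon gave only a 1.6-fold higher number from compound 1 to compound 2 (0.20 log units; within the scatter) overall, so swapping within that group is expected to bring no step beyond the scatter in this assay for compound 3. Within the data shown here, no measured compound carries 2-carboxyethyl, so the range stays wide. The expected shift is a 1.2-fold lower number from compound 2 to compound 3 (0.07 log units; within the scatter) as an estimate only. The estimate for compound 3 is 40000 nM with 20000 nM to 80000 nM as its expected range.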

Compound 3, half-maximal inhibitory concentration: 26900 nM
Compound 3: middle estimate off by 1.5-fold (0.17 log units), on the high side; the measured number falls inside the stated range.
By their numbers in this assay, from the lowest: compounds 3, 1 and 2 (each within the scatter of the next).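

In this assay, 2-carboxyethyl on the amine nitrogen in place of 1-carboxy-3-(methylsulfanyl)propyl gives a 1.8-fold lower number from compound 2 to compound 3 (0.25 log units; within the scatter), so losing the sulfur-bearing chain and its defined stereocentre brings no change that can be told from the scatter. The comparison with hydrogen on the double-bonded ring carbon gives a 1.1-fold lower number from compound 1 to compound 3 (0.05 log units; within the scatter), so now two different carboxy chains attached through an amine nitrogen at this place both stay within the scatter of compound 1. There is no supporting information that could explain why these numbers sit so close together.

All the groups compared here at this place that carry a chain end in a carboxylic acid. As far as these compounds go, whether a chain ending in a primary amine or an amide, or one carrying a phenyl ring, would move the number beyond the scatter remains open.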